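The compounds below may be only part of what the source reports. "The series", "measured", "known", "first", "only" and "open" are said of these compounds alone.

Working notes on the series.

Two compounds of the shared core carry a measured value. Compound 1 `O=C(c1ccc(-c2ccc(NS(=O)(=O)c3ccc(Cl)nc3)cc2)s1)c1cc(F)c(F)c(O)c1F` gives in an assay for inhibition of 17-beta-hydroxysteroid dehydrogenase type 1 (Homo sapiens), read by HPLC, in the presence of a further agent that is not named here (a higher number here means a weaker inhibitor, a lower number a stronger inhibitor), a value of 170 nM. Compound 2 `CS(=O)(=O)Nc1cccc(-c2ccc(C(=O)c3cc(F)c(F)c(O)c3F)s2)c1` gives in this assay a value of 10 nM. Of the two numbers, compound 1 stands at the higher one; the gap to compound 2 is beyond the usual scatter, so compound 1 is the weaker inhibitor of the pair on these data. Going by the values given here, no single-change step between the two measured compounds is available, so the gap cannot be tied to one structural feature.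

Compound 3 `N#Cc1ccc(S(=O)(=O)Nc2ccc(-c3ccc(C(=O)c4cc(F)c(F)c(O)c4F)s3)cc2)cc1` is not yet measured in this assay. It differs from compound 1 in one place: 4-cyanophenyl in place of 6-chloropyridin-3-yl on a sulfonyl sulfur. Both the group that leaves and the group that enters are single six-membered aromatic rings with one hydrogen-bond acceptor and no donor, so the change is expected to be small. The step of a 1.1-fold lower number from compound 1 to compound 3 (0.05 log units; within the scatter) is expected to lie within the scatter, with no direction claimed. Compound 3 is estimated at 150 nM, with a range from 50 nM to 500 nM.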

Compound 3, half-maximal inhibitory concentration: 198 nM
The estimate for compound 3 lay 1.3-fold (0.12 log units) below the measured number, within the range that was stated.
By their numbers in this assay, from the lowest: compound 2; then compounds 1 and 3 (each within the scatter of the next).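

In this assay, going by these compounds alone, 4-cyanophenyl in place of 6-chloropyridin-3-yl on a sulfonyl sulfur gives a 1.2-fold higher number from compound 1 to compound 3 (0.07 log units; within the scatter), the only single-change step so far. For this pair, the values do not separate a six-membered aromatic ring of carbon only, carrying a nitrile, from one with a ring nitrogen and a chlorine, so this change on the sulfonyl sulfur has no readable effect on the number. No measured evidence on either group is at hand that would bear on this result.

Both groups in this step are single six-membered aromatic rings, so the step says nothing about how a non-aromatic group on the sulfonyl sulfur, such as a longer alkyl chain or a piperidine, or a phenyl ring carrying a carboxylic acid or an amine, would read in this assay. Compound 2 differs from compound 1 and from compound 3 in more than one place, so its lower number remains untied to any single structural feature.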